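The source may hold more compounds than are shown below. What is called first, only, known or untested is meant among the compounds shown, and "the series" means these compounds.

Measured in a functional assay on U2OS cells (Homo sapiens) for inhibition, read by CCK-8 assay, with a stated time of 4 days; on this read-out higher numbers stand for weaker inhibition and lower numbers for stronger inhibition:
Compound 1 `COc1cc(C(=O)O)ccc1NC(=O)[C@@H]1N[C@@H](CC(C)(C)C)[C@](CNCc2ccncc2)(c2ccc(Cl)cc2F)[C@H]1c1cccc(Cl)c1F`: 370 nM
Compound 2 `COc1cc(C(=O)O)ccc1NC(=O)[C@@H]1N[C@@H](CC(C)(C)C)[C@](CNCc2ccc(O)cc2)(c2ccc(Cl)cc2F)[C@H]1c1cccc(Cl)c1F`: 500 nM
Compound 3 `COc1cc(C(=O)O)ccc1NC(=O)[C@@H]1N[C@@H](CC(C)(C)C)[C@](C)(c2ccc(Cl)cc2F)[C@H]1c1cccc(Cl)c1F`: 640 nM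

Compound 1 sits with compound 2 and compound 3 inside the usual scatter, so these numbers do not separate the three. Compound 4 `COc1cc(C(=O)O)ccc1NC(=O)[C@@H]1N[C@@H](CC(C)(C)C)[C@](CNCc2cccnc2)(c2ccc(Cl)cc2F)[C@H]1c1cccc(Cl)c1F` keeps the core of compound 1 and differs only in its terminal ring: pyridin-3-yl in place of pyridin-4-yl on a saturated chain carbon bound to an amine nitrogen. Going by the values given here, two measured steps bear on this. Exchanging the ring gave a 1.4-fold higher number from compound 1 to compound 2 (0.13 log units; within the scatter), and removing the whole ((pyridin-4-yl)methyl)amino group gave a 1.7-fold higher number from compound 1 to compound 3 (0.24 log units; within the scatter). Since neither of these larger changes moved the number beyond the scatter, the smaller ring change is expected to leave this assay without a clear shift in either direction. The expected size is a 1.1-fold higher number from compound 1 to compound 4 (0.06 log units; within the scatter), which is no step beyond the scatter. For compound 4 the estimate is 420 nM, with an expected range of 210 nM to 840 nM.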

Compound 4, half-maximal inhibitory concentration: 860 nM
The estimate for compound 4 lay 2.0-fold (0.31 log units) below the measured number; measured number outside the range, above it.
By their numbers in this assay, from the lowest: compounds 1, 2, 3 and 4 (each within the scatter of the next, the first and the last beyond it).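

Going by these compounds alone, with the same atoms joined differently, pyridin-3-yl in place of pyridin-4-yl gives a 2.3-fold higher number from compound 1 to compound 4 (0.37 log units; beyond the scatter) and is a modest step beyond the scatter, so this ring exchange alone registers at this position, as no earlier step did. Still, a 1.7-fold higher number from compound 2 to compound 4 (0.24 log units; within the scatter) and a 1.3-fold higher number from compound 3 to compound 4 (0.13 log units; within the scatter) both lie within the scatter, so compound 4 stands apart only from compound 1. Nothing measured here explains the step. On these data alone, whether pyridin-2-yl or a plain phenyl ring on the same chain carbon would track compound 1 or compound 4 stays open, as does the effect of a longer chain.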